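Cyclohexyl for cyclopentyl on the carbonyl of compound 2

The source may hold more compounds than are shown below. What is called first, only, known or untested is meant among the compounds shown, and "the series" means these compounds.

In an assay on isolated protein for inhibition of Nitric oxide synthase, inducible (Homo sapiens), read by scintillation counting, with a stated time of 30 min, tested at 50 uM (a lower number here means less inhibition, a higher number more inhibition at the concentration tested (going by the name of the read-out)), compound 1 `COc1ccc(N)c(C2=NN(C(=O)C3CCCCC3)C(C)(C)S2)c1` gives 100%. Compound 2 `CC1(C)SC(c2cc(Cl)ccc2N)=NN1C(=O)C1CCCC1` stands lowest of the two numbers in this assay with 21.3%, and its nearest neighbour is compound 1, whose number lies higher by a gap beyond the usual scatter. Among the measured compounds shown here, the pair differ in more than one place, so no single step connects them.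

Compound 3 `CC1(C)SC(c2cc(Cl)ccc2N)=NN1C(=O)C1CCCCC1` has not yet been measured in this assay. It differs from compound 2 in one place: cyclohexyl in place of cyclopentyl on a carbonyl carbon. No measured step of this kind is on record among these compounds, so the size of the change can only be guessed. Compound 3 is expected to show a moderate rise, a number 23.7 percentage points higher from compound 2 to compound 3 (beyond the scatter), in this assay. Compound 3 is therefore estimated at 45%, within a range from 15% to 85%.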

Compound 3, a percentage reported as inhibition, at one concentration (the size of the read-out at that concentration, not a potency): 7.61%
The estimate for compound 3 lay 37.4 percentage points above the measured number; measured number below the stated range.
By their numbers in this assay, from the lowest: compound 3; then compound 2; then compound 1.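

In this assay, the change from cyclopentyl to cyclohexyl on the carbonyl carbon lowers the number, a number 13.7 percentage points lower from compound 2 to compound 3 (beyond the scatter), so among the chloro compounds the six-membered ring gives less inhibition than the five-membered one. With cyclohexyl held in place, the aromatic carbon proves far more telling: chloro in place of methoxy gives a number 92.4 percentage points lower from compound 1 to compound 3 (beyond the scatter), a much larger step than the ring change. Nothing available explains either step.

On these data alone, what remains open is whether methoxy keeps its advantage with cyclopentyl on the carbonyl carbon, so that the two changes could be judged independently of each other. Also open, as far as these compounds go, is how ethoxy or fluoro on the aromatic carbon, or an open chain such as n-butyl on the carbonyl carbon, would read in this assay.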